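The source may hold more compounds than are shown below. What is called first, only, known or untested is meant among the compounds shown, and "the series" means these compounds.

Measured compounds and their values:
compound 1 `CC(=O)OC/C(=C\c1ccc(Cl)cc1Cl)C(=O)c1ccccc1` — 14000 nM
compound 2 `CC(=O)OC/C(=C/c1ccccc1Cl)C(=O)c1ccccc1` — 22000 nM
compound 3 `CC(=O)OC/C(=C/c1ccccc1Br)C(=O)c1ccccc1` — 18000 nM

In a functional assay on WiDr cells (Homo sapiens) for inhibition, read by sulforhodamine B assay, with a stated time of 48 h (on this read-out lower numbers stand for stronger inhibition of growth and higher numbers for weaker inhibition of growth), compound 2 gives 22000 nM, the highest of the three numbers, yet its gap to compound 3 and its gap to compound 1 both lie within the scatter of this assay, so no order among them can be claimed. Compound 4 `CC(=O)OC/C(=C/c1ccc(Cl)cc1Cl)C(=O)c1ccccc1` has not yet been measured; it differs from compound 2 in one place: chloro in place of hydrogen on an aromatic carbon. For the measured compounds named here, only one measured step bears on this change, and only loosely: a 1.2-fold lower number from compound 2 to compound 3 (0.09 log units; within the scatter), a halogen swap at the same position rather than an added halogen. Compound 1 carries the same two chloro groups as compound 4 but differs from it elsewhere in the shared core, and its value and that of compound 2 are within the scatter of each other. Nothing here points to a shift beyond the scatter, so compound 4 is expected to give 18000 nM (range 9000 nM to 36000 nM), an estimated step of a 1.2-fold lower number from compound 2 to compound 4 (0.09 log units; within the scatter).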

Compound 4, concentration for 50% growth inhibition: 19000 nM
Estimate against measurement, compound 4: 1.1-fold (0.02 log units) below; the measured number falls inside the stated range.
By their numbers in this assay, from the lowest: compounds 1, 3, 4 and 2 (each within the scatter of the next).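

Setting a chloro group in place of hydrogen on the aromatic ring gives, in this assay, a 1.2-fold lower number from compound 2 to compound 4 (0.06 log units; within the scatter), so a halogen added at this position, and not only a halogen swapped for another, stays inside the usual scatter. For the compounds shown here, the new pair also tests something the earlier compounds could not, the way the double bond is drawn, and it gives a 1.4-fold higher number from compound 1 to compound 4 (0.13 log units; within the scatter), so no effect of this configuration can be read in this assay. That comparison is a clean one, with nothing else to confuse it: the fact that compounds 1 and 4 differ only in the configuration as drawn.

The ring groups shown are only chloro and bromo, and every compound lies within the scatter of the next, so nothing yet shows what would separate these compounds. On these data alone, whether an amine or a carboxylic acid at this position would give a step beyond the scatter remains open.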